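A Methoxy Group Added to the Phenyl Ring

The source may report more compounds than this note shows. Statements on the series, on what has been measured and on what is new or still open speak of the compounds shown alone.

Of the compounds shown here, three sharing one core have been measured in a functional assay on OVCAR-5 cells (Homo sapiens) for inhibition; on this read-out higher numbers stand for weaker inhibition of growth and lower numbers for stronger inhibition of growth. Compound 1 `COc1cc(/C=C/C(=O)c2cccc(-n3cc(-c4ccccc4)[nH]c3=O)c2)ccc1O` gives 2040 nM, the lowest number of the three, with compound 3 `O=C(/C=C/c1cccc(O)c1)c1cccc(-n2cc(-c3ccc(Cl)cc3)[nH]c2=O)c1` close at 2190 nM and compound 2 `O=C(/C=C/c1cccc(O)c1)c1cccc(-n2cc(-c3ccccc3)[nH]c2=O)c1` furthest at 5440 nM. Compound 4 `COc1ccc(-c2cn(-c3cccc(C(=O)/C=C/c4ccc(O)c(OC)c4)c3)c(=O)[nH]2)cc1` differs from compound 1 in one place: methoxy in place of hydrogen on an aromatic carbon, or read one bond further out, phenyl to 4-methoxyphenyl. The step that bears on this adds a group to the same ring: a 2.5-fold lower number from compound 2 to compound 3 (0.40 log units; beyond the scatter). The other step, a 2.7-fold higher number from compound 1 to compound 2 (0.43 log units; beyond the scatter), concerns a different part of the molecule and tells less. A modest lowering is therefore expected, a 1.5-fold lower number from compound 1 to compound 4 (0.16 log units; within the scatter). Compound 4 is estimated at 1400 nM, between 600 nM and 3500 nM.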

Compound 4, concentration for 50% growth inhibition: 3380 nM
The estimate for compound 4 lay 2.4-fold (0.38 log units) below the measured number, within the range that was stated.
By their numbers in this assay, from the lowest: compounds 1, 3, 4 and 2 (each within the scatter of the next, the first and the last beyond it).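

Put on an aromatic carbon para to a large group, methoxy gives a 1.7-fold higher number from compound 1 to compound 4 (0.22 log units; within the scatter) in this assay, so no real change can be claimed. The lowering seen with chloro on this ring, a 2.5-fold lower number from compound 2 to compound 3 (0.40 log units; beyond the scatter), was measured with a different group on the other end of the molecule, and methoxy on the core of compound 1 does not repeat it. Nothing available explains this difference.

Going by these compounds, whether an amine or an ethoxy group on this carbon would move the number beyond the scatter remains open. So does whether chloro would lower the number on the core of compound 1.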